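Swapping halogens on the hydrazone aryl ring

The source may hold more compounds than are shown below. What is called first, only, known or untested is meant among the compounds shown, and "the series" means these compounds.

Measured so far:
compound 1 `COc1cc(C(=O)N/N=C/c2ccccc2C(F)(F)F)cc(OC)c1OC` gives 22.1%
compound 2 `COc1cc(C(=O)N/N=C/c2ccc(F)c(F)c2)cc(OC)c1OC` gives 33.1%

In a functional assay on BGC-823 cells (Homo sapiens) for antiproliferative activity, read by MTT assay, tested at 1 uM (a lower number here means a weaker effect, a higher number a stronger effect of the compound at the concentration tested), compound 2 stands highest of the two numbers, and its nearest neighbour, compound 1, lies beyond the scatter below it. Compound 3 `COc1cc(C(=O)N/N=C/c2cc(Cl)cc(Cl)c2)cc(OC)c1OC` has not yet been measured. It differs from compound 2 in one place: 3,5-dichlorophenyl in place of 3,4-difluorophenyl on a carbon with a double bond to nitrogen. Within the data shown here, no measured pair shows how such a change acts in this assay, so the step from compound 2 to compound 3 is expected to be small, probably within the scatter, in no sure direction. Compound 3 is therefore expected to give 30% in this assay, somewhere from 15% to 50%, an expected step of a number 3.1 percentage points lower from compound 2 to compound 3 (within the scatter).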

Compound 3, a percentage reported as inhibition, at one concentration (the size of the read-out at that concentration, not a potency): -7.5%
Compound 3: middle estimate off by 37.5 percentage points, on the high side, outside the stated range (below it).
By their numbers in this assay, from the lowest: compound 3; then compound 1; then compound 2.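

The aryl group on a carbon with a double bond to nitrogen proves highly sensitive: in this assay, 3,5-dichlorophenyl in place of 3,4-difluorophenyl gives a number 40.6 percentage points lower from compound 2 to compound 3 (beyond the scatter). Two halogens on the ring are therefore no guarantee of keeping the effect, even with the same count of heavy atoms in both groups. Nothing available explains this drop. The compounds shown leave open whether the change of halogen or its placement on the ring accounts for the step. From the compounds shown here alone, how a ring carrying an amine or a carboxylic acid would behave also remains open.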